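The source may report more compounds than this note shows. Statements on the series, on what has been measured and on what is new or still open speak of the compounds shown alone.

Measured so far:
- Compound 1 `COc1ccc(C(F)(F)F)cc1Nc1ncc(C(F)(F)F)c(N2Cc3cccc(N(C)S(C)(=O)=O)c3C2)n1`: in a functional assay on OVCAR-3 cells (Homo sapiens) for antiproliferative activity, read by spectrophotometry, with a stated time of 2 days (on this read-out higher numbers stand for weaker inhibition of growth and lower numbers for stronger inhibition of growth), compound 1 gives > 30000 nM, which is a limit of the assay and not a number.
- Compound 2 `COc1cc(Nc2ncc(C(F)(F)F)c(N3Cc4cccc(N(C)S(C)(=O)=O)c4C3)n2)cc(OC)c1`: in this assay compound 2 gives 630 nM.
- Compound 3 `CC(=O)N1CCN(c2ccc(Nc3ncc(C(F)(F)F)c(N4Cc5cccc(N(C)S(C)(=O)=O)c5C4)n3)cc2)CC1`: in this assay compound 3 gives 970 nM.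

Of the two numbers shown, compound 2 and compound 3 sit within the scatter of each other and cannot be ranked; the remaining value, that of compound 1, is a limit. Going by the values given here, only one step between measured compounds changes a single place, and it is large: an at least 47-fold lower number from compound 1 to compound 2 (1.67 log units; beyond the scatter). Its true size is not fully known, since the value of compound 1 rests on a limit (the limit of > 30000 nM in this assay, at which 1 of the 3 values shown sits).

Compound 4 `CN(c1cccc2c1CN(c1nc(Nc3cc(Cl)cc(C(F)(F)F)c3)ncc1C(F)(F)F)C2)S(C)(=O)=O` differs from compound 2 in that same place: 3-chloro-5-(trifluoromethyl)phenyl in place of 3,5-dimethoxyphenyl on a nitrogen on an aromatic ring. Among the compounds with values here, this brings back a ring carrying trifluoromethyl, as compound 1 carries, though the pattern of groups on the ring is not the same, so the one measured step is only a rough guide. It points toward a weaker result in this assay, with a real chance that only a limit is reported. Compound 4 is therefore expected near 6000 nM, within a range from 1200 nM to 30000 nM. That estimate means a step of a 9.5-fold higher number from compound 2 to compound 4 (0.98 log units; beyond the scatter).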

Compound 4, concentration for 50% growth inhibition: 21500 nM
Compound 4: the middle estimate sits 3.6-fold (0.55 log units) below what was measured, within the range that was stated.
By their numbers in this assay, from the lowest: compounds 2 and 3 (each within the scatter of the next); then compound 4. At a limit, above all of these: compound 1.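

In this assay, 3-chloro-5-(trifluoromethyl)phenyl in place of 3,5-dimethoxyphenyl on a nitrogen on an aromatic ring gives a 34-fold higher number from compound 2 to compound 4 (1.53 log units; beyond the scatter), so a second swap of the 3,5-dimethoxyphenyl group also moves the result far beyond the scatter, and this time the size of the step is known. Among the four compounds, the two whose rings carry trifluoromethyl, compound 1 and compound 4, both sit on the weaker side of compound 2, even though one of these rings keeps a methoxy group and the other has none, but four compounds are too few to call this a rule. 3-chloro-5-(trifluoromethyl)phenyl in place of 2-methoxy-5-(trifluoromethyl)phenyl on a nitrogen on an aromatic ring gives an at least 1.3-fold lower number from compound 1 to compound 4 (0.14 log units; that floor lies within the scatter). The full size of that step cannot be read, because the value of compound 1 is a limit and not a number: the limit of > 30000 nM in this assay, at which 1 of the 4 values shown sits.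

Chlorine and trifluoromethyl enter together in compound 4, so the compounds shown leave open which of the two goes with the higher number, or whether it is the loss of the methoxy groups that matters. They also leave open how a ring carrying a nitrile, an amine or a carboxylic acid would read at this place.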